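Swapping a Cyclobutyl for a Methyl on a Urea Series

The source may report more compounds than this note shows. Statements on the series, on what has been measured and on what is new or still open speak of the compounds shown alone.

Of the compounds shown here, three sharing one urea core have been tested in a functional assay on HT-29 cells (Homo sapiens) for inhibition, read by MTT assay, with a stated time of 120 h; on this read-out lower numbers stand for stronger inhibition and higher numbers for weaker inhibition. Compound 1 `O=C(/C=C/c1ccc(NC(=O)Nc2ccc(Cl)c(C(F)(F)F)c2)cc1)NC1CCC1` gives 4430 nM. Compound 2 `CNC(=O)/C=C/c1ccc(NC(=O)Nc2ccc(Cl)c(C(F)(F)F)c2)cc1` gives 11700 nM. Compound 3 `O=C(CCc1ccc(NC(=O)Nc2ccc(Cl)c(C(F)(F)F)c2)cc1)NC1CCC1` gives 21300 nM. Compound 4 `CNC(=O)CCc1ccc(NC(=O)Nc2ccc(Cl)c(C(F)(F)F)c2)cc1` has not yet been measured.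

Compound 2 differs from compound 1 by methyl in place of cyclobutyl on an amide-type nitrogen, and this gave a 2.6-fold higher number from compound 1 to compound 2 (0.42 log units; beyond the scatter). Compound 3 differs from compound 1 in the core by 2-(cyclobutylcarbamoyl)ethyl in place of 2-(cyclobutylcarbamoyl)ethenyl on an aromatic carbon, which gave a 4.8-fold higher number from compound 1 to compound 3 (0.68 log units; beyond the scatter). Between compound 2 and compound 3 the data show a 1.8-fold higher number from compound 2 to compound 3 (0.26 log units; within the scatter).

Compound 4 differs from compound 3 by methyl in place of cyclobutyl on an amide-type nitrogen, the same change as that from compound 1 to compound 2, at the same place. If the change behaves as before, compound 4 is expected to show a 2.3-fold higher number from compound 3 to compound 4 (0.37 log units; beyond the scatter), resting on the earlier step of a 2.6-fold higher number from compound 1 to compound 2 (0.42 log units; beyond the scatter) and on the starting value of compound 3 21300 nM. Compound 4 is therefore estimated at 50000 nM, with a likely range from 20000 nM to 120000 nM; a weak reading near the top of the tested range may instead come back only as a limit.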

Compound 4, half-maximal inhibitory concentration: 20600 nM
Estimate against measurement, compound 4: 2.4-fold (0.39 log units) above; measured number inside the range.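

In this assay, the same swap of cyclobutyl for methyl on the core of compound 3 gives a 1.0-fold lower number from compound 3 to compound 4 (0.01 log units; within the scatter), so the change does not carry over with the size it had on the core of compound 1, and the two steps differ: the same change on two cores in this assay, a 2.6-fold higher number (0.42 log units; beyond the scatter) from compound 1 to compound 2 and a 1.0-fold lower number (0.01 log units; within the scatter) from compound 3 to compound 4, 2.7-fold (0.44 log units) apart, beyond the scatter of two such steps On the methyl side, 2-(methylcarbamoyl)ethyl in place of 2-(methylcarbamoyl)ethenyl gives a 1.8-fold higher number from compound 2 to compound 4 (0.25 log units; within the scatter), while the wider comparison, which alters both places at once, gives a 4.7-fold higher number from compound 1 to compound 4 (0.67 log units; beyond the scatter), leaving compound 1 with the lowest number of the four. This shows that the step from cyclobutyl to methyl cannot simply be added on whatever the core, but two cores are too few to show why it differs or what it would do on a third.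

The compounds shown leave open how other groups on the amide-type nitrogen, such as cyclopropyl or 2-hydroxyethyl, would read on each core. They also leave open what a longer chain in place of 2-(methylcarbamoyl)ethyl would do.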